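This account rests on a few compounds, and the source may have more. Where it says the series, first, only, none or still open, it means among the compounds named here.

Measured compounds in this series:

Compound 1 `CNC(=O)c1ccc(-c2ccc(Cl)cc2)c(N)n1` in an assay on HEK293 cells for inhibition of sodium channel protein type 10 subunit alpha (Homo sapiens), read by fluorescence (on this read-out higher numbers stand for weaker inhibition and lower numbers for stronger inhibition), gives a limit of the assay, > 32000 nM, not a number.
Compound 2 `CNC(=O)c1ccc(-c2cc(Cl)cc(Cl)c2)c(N)n1` in this assay also gives a limit, > 32000 nM.
Compound 3 `Cn1nccc1C(=O)Nc1ccc(-c2cc(Cl)cc(Cl)c2Cl)c(N)n1` in this assay gives 750 nM.

Compound 3 is thus the only one of the three with a measured number; the other two sit at the limit of > 32000 nM in this assay, at which 2 of the 3 values shown sit. Within the data shown here, no step between measured compounds that differ in a single place can be stated, so the two limits and the single number are taken only as they stand: compound 3 is the one entry with a quantified value in this assay.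

Compound 4 `Cc1nocc1C(=O)Nc1ccc(-c2cc(Cl)cc(Cl)c2Cl)c(N)n1` is the next compound to be measured. It differs from compound 3 by 3-methyl-1,2-oxazol-4-yl in place of 1-methyl-1H-pyrazol-5-yl on a carbonyl carbon. The amide, the shared core and the trichlorophenyl ring are kept; only the five-membered ring on the carbonyl carbon changes, one ring with two hetero atoms for another of the same size.

With no measured step of this kind in the series, the expectation for compound 4 is a change close to the scatter, if anything toward weaker inhibition. Compound 4 is estimated at 1100 nM, with a range of 300 nM to 4500 nM. The step that this estimate implies, a 1.5-fold higher number from compound 3 to compound 4 (0.17 log units; within the scatter), is expected to stay small.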

Compound 4, half-maximal inhibitory concentration in the sodium channel protein type 10 subunit alpha assay: 670 nM
Estimate against measurement, compound 4: 1.6-fold (0.22 log units) above; the measured number falls inside the stated range.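

Among these compounds, in the sodium channel protein type 10 subunit alpha assay, 3-methyl-1,2-oxazol-4-yl in place of 1-methyl-1H-pyrazol-5-yl on a carbonyl carbon gives a 1.1-fold lower number from compound 3 to compound 4 (0.05 log units; within the scatter), the first step that can be read. At this position, one five-membered aromatic ring with 2 hetero atoms can therefore replace another, with one ring nitrogen count traded for oxygen and the methyl group placed differently in the ring name, without a measurable change in this read-out. In a physicochemical assay for solubility, at pH 7.2 (on this read-out higher numbers stand for higher solubility and lower numbers for lower solubility), compound 3 gives a limit, < 0.1 ug/mL, not a number. In the physicochemical assay compound 4 also gives a limit, < 0.1 ug/mL, not a number. In the physicochemical assay the step cannot be read, and neither ring takes the read-out off the limit: the limit of < 0.1 ug/mL in the physicochemical assay, at which 2 of the 2 values shown sit.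

Going by these compounds, whether an amine, a carboxylic acid or a longer chain in place of these rings on the carbonyl carbon would keep the number in the sodium channel protein type 10 subunit alpha assay and bring the read-out in the physicochemical assay off its limit remains open. In the sodium channel protein type 10 subunit alpha assay, compound 1 and compound 2 each differ from compound 3 in more than one place, and which of those differences separates compound 3 from the values that are only limits also remains open: the limit of > 32000 nM in the sodium channel protein type 10 subunit alpha assay, at which 2 of the 4 values shown sit.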